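Removing One Methoxy From Compound 2: An Expected Outcome

A few compounds are considered here, and "the series" means these few. Any claim that something is new, unique, unknown or untested is made for them only; others in the source may bear on it.

Compound 2 `COc1ccc(C(=O)/C=C/c2cc(-c3cc(OC)c(OC)c(OC)c3)n[nH]2)cc1OC` gives 6700 nM in a functional assay on HCC 2998 cells (Homo sapiens) for inhibition, read by sulforhodamine B assay, with a stated time of 48 h (a higher number here means that more compound is tolerated, a lower number that less compound is tolerated), and it stands together with compound 1 `COc1cc(-c2cc(/C=C/C(=O)c3ccc(N)cc3)[nH]n2)cc(OC)c1OC`, which gives 6530 nM; the step of a 1.0-fold higher number from compound 1 to compound 2 (0.01 log units; within the scatter) shows the two cannot be told apart. Compound 3 `COc1ccc(C(=O)/C=C/c2cc(-c3cc(OC)c(OC)c(OC)c3)n[nH]2)cc1` has not yet been measured and differs from compound 2 by hydrogen in place of methoxy on an aromatic carbon. Among the measured compounds shown here, the only measured step also alters the ring on the carbonyl carbon, and since a 1.0-fold higher number from compound 1 to compound 2 (0.01 log units; within the scatter) left the number unchanged, a smaller change on that ring is expected to do the same, giving no step beyond the scatter. Compound 3 is therefore expected to give 6500 nM (range 2500 nM to 17000 nM), a step of a 1.0-fold lower number from compound 2 to compound 3 (0.01 log units; within the scatter).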

Compound 3, concentration lethal to 50% of the cells: 6480 nM
The estimate for compound 3 lay 1.0-fold (0.00 log units) above the measured number; low and high end bracket the measured number.
By their numbers in this assay, from the lowest: compounds 3, 1 and 2 (each within the scatter of the next).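

Taking one methoxy off the ring, so that 3,4-dimethoxyphenyl becomes 4-methoxyphenyl, leaves this assay unmoved (a 1.0-fold lower number from compound 2 to compound 3 (0.01 log units; within the scatter)). Methoxy in place of amino on that ring also makes no readable difference (a 1.0-fold lower number from compound 1 to compound 3 (0.00 log units; within the scatter)), so all three groupings on this ring cannot be told apart here. No measurement bears on why the number stays put.

From the compounds shown here alone, whether a plain phenyl ring, with no methoxy left, would also sit within the scatter stays open. So does the effect on the number of a carboxylic acid or a longer chain on this ring.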